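Series notes: alkyne substituents on the shared core

This account rests on a few compounds, and the source may have more. Where it says the series, first, only, none or still open, it means among the compounds named here.

Measured so far:
compound 1, `CONc1nc(C#CCCCC#N)nc2c1ncn2[C@@H]1O[C@H](CO)[C@@H](O)[C@H]1O`, 4.1 nM
compound 2, `CONc1nc(C#CCC(C)O)nc2c1ncn2[C@@H]1O[C@H](CO)[C@@H](O)[C@H]1O`, 5.4 nM
compound 3, `CONc1nc(C#CC2CCCCC2O)nc2c1ncn2[C@@H]1O[C@H](CO)[C@@H](O)[C@H]1O`, 1.7 nM

In an assay on CHO cells for displacement of a labelled ligand from adenosine receptor A3 (Homo sapiens) (on this read-out higher numbers stand for weaker inhibition and lower numbers for stronger inhibition), compound 3 gives the lowest of the three numbers. Its nearest neighbour is compound 1, a 2.4-fold lower number from compound 1 to compound 3 (0.38 log units; beyond the scatter); the furthest is compound 2, a 3.2-fold lower number from compound 2 to compound 3 (0.50 log units; beyond the scatter). Compounds 1 and 2 themselves lie close together, a 1.3-fold higher number from compound 1 to compound 2 (0.12 log units; within the scatter).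

Compound 4, `CONc1nc(C#Cc2ccccn2)nc2c1ncn2[C@@H]1O[C@H](CO)[C@@H](O)[C@H]1O`, is not yet measured. The change from compound 3 is pyridin-2-yl in place of 2-hydroxycyclohexyl on a triple-bonded carbon. Among the compounds with values here, none of the measured steps covers this change: all three measured compounds carry a saturated group on the triple-bonded carbon, and each carries a hydroxy or nitrile group; compound 4 carries an aromatic ring with no hydrogen-bond donor. The measured steps only show that moving among the three saturated groups shifts this assay by modest amounts in either direction, none large. Two of those steps run beyond the scatter, one within.

Within the data shown here, with no directly comparable step, the expectation for compound 4 is that it stays within the range spanned by compounds 1 to 3, most likely somewhat weaker than compound 3, a step of a 2.4-fold higher number from compound 3 to compound 4 (0.37 log units; beyond the scatter). Compound 4 is therefore estimated at 4 nM, with a range from 1.5 nM to 12 nM.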

Compound 4, inhibition constant: 2.3 nM
Compound 4: the middle estimate sits 1.7-fold (0.24 log units) above what was measured, and the stated range covers the measured number.
By their numbers in this assay, from the lowest: compounds 3, 4, 1 and 2 (each within the scatter of the next, the first and the last beyond it).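

Pyridin-2-yl is the first aromatic ring in the series on a triple-bonded carbon, and in this assay its exchange for 2-hydroxycyclohexyl reads (a 1.4-fold higher number from compound 3 to compound 4 (0.13 log units; within the scatter)), so within the compounds shown neither a saturated ring nor a hydrogen-bond donor in this group is required for a low number. Against the open-chain groups the picture is split, with the exchange for 2-hydroxypropyl reading (a 2.3-fold lower number from compound 2 to compound 4 (0.37 log units; beyond the scatter)) and the exchange for 3-cyanopropyl reading (a 1.8-fold lower number from compound 1 to compound 4 (0.25 log units; within the scatter)), so the aromatic ring does not separate cleanly from the saturated groups as a class. No supporting data accompany these results that would bear on their origin.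

Whether the ring nitrogen of pyridin-2-yl contributes stays open, since the compounds shown include no phenyl group on the triple-bonded carbon for a direct comparison with compound 4. It also stays open whether this position would keep numbers in the same narrow band with an amine, a carboxylic acid or a longer chain in place of these groups, or how any of these compounds reads at other adenosine receptors.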